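Lengthening a hydroxymethyl to hydroxyethyl on a shared core

A few compounds are considered here, and "the series" means these few. Any claim that something is new, unique, unknown or untested is made for them only; others in the source may bear on it.

Compound 1 `Cc1nc(C(NC(=O)C(=O)Nc2ccc(F)c(F)c2)C2CCCCN2)sc1CO`: in an ADME assay on TZM-b1 cells (Homo sapiens) for cytotoxicity, read by XTT assay, with a stated time of 3 days (a higher number here means that more compound is tolerated, a lower number that less compound is tolerated), compound 1 gives > 87000 nM, a limit of the assay rather than a number.
Compound 2 `Cc1nc(C(NC(=O)C(=O)Nc2ccc(F)cc2F)C2CCCCN2)sc1CO`: in this assay compound 2 gives > 87000 nM, again a limit.
Compound 3 `Cc1nc(C(NC(=O)C(=O)NC2CCCCCC2)C2CCCCN2)sc1CO`: in this assay compound 3 gives > 90000 nM, also a limit.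

Compound 1 therefore stands only at a limit, and so do its two neighbours; none of the three has a true number. Compound 4 `Cc1nc(C(NC(=O)C(=O)Nc2ccc(F)c(F)c2)C2CCCCN2)sc1CCO` differs from compound 1 in one place: hydroxymethyl in place of hydroxy on a saturated chain carbon bound to an aromatic carbon. The three measured steps all concern a different position, the amide-type nitrogen, and each is unreadable: a step that the two limits leave unreadable from compound 1 to compound 2, a step that the two limits leave unreadable from compound 1 to compound 3 and a step that the two limits leave unreadable from compound 2 to compound 3. The reason they cannot be read is that the values sit at the limit of > 87000 nM in this assay, at which 2 of the 3 values shown sit, and at the limit of > 90000 nM in this assay, at which 1 of the 3 values shown sits, so no direction or size can be drawn from them. Nothing measured here speaks to a change on the saturated chain carbon bound to the aromatic carbon. With every comparable compound ending at a limit, the expectation for this assay is no readable step, and the step from compound 1 to compound 4 is expected to be a step that the limit leaves unreadable from compound 1 to compound 4. Compound 4 is estimated at 90000 nM, most likely reported as a limit again, within a range from 40000 nM to 200000 nM.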

Compound 4, half-maximal cytotoxic concentration: > 78200 nM
Compound 4: no number, only a limit; the forecaster's own chance of this, stated with the estimate: 85%; the middle value does not contradict the limit.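

In this assay compound 4 gives > 78200 nM, a limit and not a number. Compound 1 also stands only at a limit, and the step from compound 1 to compound 4 cannot be read. The compounds shown leave open the concentration at which any of them harms these cells, and whether hydroxymethyl to 2-hydroxyethyl shifts it.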